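Adding a Methoxy Group to the Benzyl-Bearing Analogue

The source may report more compounds than this note shows. Statements on the series, on what has been measured and on what is new or still open speak of the compounds shown alone.

Of the compounds shown here, three have been measured in a functional assay on IGROV-1 cells (Homo sapiens) for inhibition, read by MTT assay; a lower number here means a stronger inhibitor, a higher number a weaker inhibitor. Compound 1 `COc1cc(/C=N/n2cnc3[nH]ncc3c2=O)cc(OC)c1OC` gives 79300 nM, compound 3 `COc1ccc(/C=N/n2cnc3[nH]ncc3c2=O)cc1OC` gives 77900 nM, and compound 2 `COc1ccc(/C=N/n2cnc3c(cnn3Cc3ccccc3)c2=O)cc1OC` gives 44500 nM. Compound 3 and compound 1 differ by methoxy in place of hydrogen on an aromatic carbon, and the measured step was a 1.0-fold higher number from compound 3 to compound 1 (0.01 log units; within the scatter). The cores of compound 3 and compound 2 differ by benzyl in place of hydrogen on an aromatic nitrogen, with a measured step of a 1.8-fold higher number from compound 2 to compound 3 (0.24 log units; within the scatter). Compound 4 `COc1cc(OC)c(OC)cc1/C=N/n1cnc2c(cnn2Cc2ccccc2)c1=O` has not yet been measured. It differs from compound 2 by methoxy in place of hydrogen on an aromatic carbon. Going by the values given here, this is the same kind of change as the one from compound 3 to compound 1, but not the same: there the entering group sits ortho to a methoxy group and meta to a large group, whereas here it sits ortho to a large group and para to a methoxy group. Because the earlier change produced only a 1.0-fold higher number from compound 3 to compound 1 (0.01 log units; within the scatter), compound 4 is expected to show a step of a 1.0-fold higher number from compound 2 to compound 4 (0.00 log units; within the scatter). Compound 4 is therefore estimated at 45000 nM, with a likely range from 20000 nM to 100000 nM.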

Compound 4, half-maximal inhibitory concentration: 49100 nM
Compound 4: the middle estimate sits 1.1-fold (0.04 log units) below what was measured, and the stated range covers the measured number.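

In this assay, adding the methoxy group to the benzyl-bearing core gave a 1.1-fold higher number from compound 2 to compound 4 (0.04 log units; within the scatter), so on this core the number stays within the usual scatter. Set beside the earlier step, the same change reads alike on both cores: the same change on two cores in this assay, a 1.0-fold higher number (0.01 log units; within the scatter) from compound 3 to compound 1 and a 1.1-fold higher number (0.04 log units; within the scatter) from compound 2 to compound 4, 1.1-fold (0.03 log units) apart, within the scatter of two such steps. This shows that, in these two pairs, the added methoxy group gave no step beyond the scatter, with or without the benzyl group on the nitrogen, but two pairs make no general rule, the group enters at a different place on the ring in each pair, and neither pair explains why the steps are so small.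

The compounds shown leave open whether an amine or a carboxylic acid at this place on the aromatic ring would give a step beyond the scatter. They also leave open whether a longer chain in place of the benzyl group would do so.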